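This account rests on a few compounds, and the source may have more. Where it says the series, first, only, none or still open, it means among the compounds named here.

Compound 1, `O=C(O)CNC(=O)c1c(O)c2c(n(Cc3ccc(C(F)(F)F)cc3)c1=O)COC2`, gives 4.2 10^-6 cm/s in an ADME assay on LLC-PK1 cells (Sus scrofa) for permeability, with a stated time of 3 h, tested at 1 uM; a lower number here means that the compound crosses the layer more slowly, a higher number that the compound crosses the layer faster.
Compound 2, `O=C(O)CNC(=O)c1c(O)c2c(n(Cc3ccc(Cl)cc3)c1=O)COC2`, gives 2.5 10^-6 cm/s in this assay.
Compound 3, `CC(C)(O)c1ccc(Cn2c3c(c(O)c(C(=O)NCC(=O)O)c2=O)COC3)cc1`, reaches only a limit in this assay, namely < 1.5 10^-6 cm/s.

Among the two numbers shown, compound 2 stands lowest; the nearest is compound 1, and the step of a 1.7-fold lower number from compound 1 to compound 2 (0.23 log units; within the scatter) is within the scatter. The limit of compound 3 sets (the limit of < 1.5 10^-6 cm/s in this assay, at which 1 of the 3 values shown sits).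

Compound 4, `O=C(O)CNC(=O)c1c(O)c2c(n(Cc3nc4ccccc4o3)c1=O)COC2`, has not yet been measured. It differs from compound 2 in one place: 1,3-benzoxazol-2-yl in place of 4-chlorophenyl on a saturated chain carbon bound to an aromatic nitrogen. For the measured compounds named here, none of the measured steps touches the aromatic ring itself; a 1.7-fold lower number from compound 1 to compound 2 (0.23 log units; within the scatter), an at least 2.8-fold lower number from compound 1 to compound 3 (0.44 log units; beyond the scatter) and an at least 1.6-fold lower number from compound 2 to compound 3 (0.22 log units; that floor lies within the scatter) all exchange one substituent on the aromatic carbon and leave the 4-substituted phenyl in place. They show that a substituent swap at this site moves the number little or downward, but they say nothing direct about a 1,3-benzoxazol-2-yl with 2 hydrogen-bond acceptors in place of a 4-chlorophenyl with none. Given that, compound 4 is expected to give 1.5 10^-6 cm/s, between 0.5 10^-6 cm/s and 4 10^-6 cm/s, which means an expected step of a 1.7-fold lower number from compound 2 to compound 4 (0.22 log units; within the scatter), with a real chance that only a limit is reported.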

Compound 4, apparent permeability: < 1.9 10^-6 cm/s
Compound 4: a limit, no number; the forecaster's own chance of this, stated with the estimate: 40%; the middle value does not contradict the limit.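

The earlier steps shown here all exchanged a substituent on the aromatic carbon and left the 4-substituted phenyl in place, whereas this change replaces the whole 4-chlorophenyl on a saturated chain carbon bound to an aromatic nitrogen. In this assay it gives an at least 1.3-fold lower number from compound 2 to compound 4 (0.11 log units; that floor lies within the scatter), so a group with 2 hydrogen-bond acceptors in this place gives no reading higher than that of compound 2. Compound 4 stops at a limit of the assay, not a number: the limit of < 1.9 10^-6 cm/s in this assay, at which 1 of the 4 values shown sits.

As far as these compounds go, how far compound 4 lies under that limit remains open, and so does the size of the step. The compounds shown also cannot separate the effect of the hetero atoms from that of the second ring, which naphthalen-2-yl, with carbon-only rings, in the same place could address.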